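Benzyl tetrazoles: cytotoxicity notes toward compound 3

A few compounds are considered here, and "the series" means these few. Any claim that something is new, unique, unknown or untested is made for them only; others in the source may bear on it.

Two compounds of this series have results in an ADME assay on CHO-K1 cells (Cricetulus griseus) for cytotoxicity, read by MTT assay, with a stated time of 24 h; on this read-out lower numbers stand for stronger inhibition and higher numbers for weaker inhibition. Compound 1 `CCCCCCCCCCCCn1nnc(-c2cc([N+](=O)[O-])cc([N+](=O)[O-])c2)n1` returns > 200000 nM, which is a limit of the assay and not a number; this is the limit of > 200000 nM in this assay, at which 1 of the 2 values shown sits. Among the measured compounds shown here, compound 2 `O=[N+]([O-])c1cc(-c2nnn(Cc3cccc(Cl)c3)n2)cc([N+](=O)[O-])c1` gives 27000 nM, the only plain number so far. For the measured compounds named here, compound 2 therefore stands alone as a measured point, and no step between measured compounds can be read off in this assay.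

Compound 3 `O=[N+]([O-])c1cc(-c2nnn(Cc3ccc(F)cc3)n2)cc([N+](=O)[O-])c1` differs from compound 2 in one place: 4-fluorophenyl in place of 3-chlorophenyl on a saturated chain carbon bound to an aromatic nitrogen. The shared core is unchanged. Going by the values given here, no measured pair shows what this change does in this assay, so the expectation rests on compound 2 alone and on the modest size of the swap. The step of a 1.3-fold higher number from compound 2 to compound 3 (0.11 log units; within the scatter) is expected to stay within the usual scatter, with no clear direction favoured. Compound 3 is accordingly estimated at 35000 nM, with a range from 12000 nM to 110000 nM, and with some chance that this assay reports only a limit for it.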

Compound 3, half-maximal inhibitory concentration: 35000 nM
Estimate against measurement, compound 3: no gap at the digits printed, within the range that was stated.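

Among the compounds shown here, the first readable step in this assay is a 1.3-fold higher number from compound 2 to compound 3 (0.11 log units; within the scatter), so the exchange of 3-chlorophenyl for 4-fluorophenyl on a saturated chain carbon bound to an aromatic nitrogen leaves the read-out unresolved from that of the earlier benzyl compound. At this position, then, two differently halogenated phenyl groups give values that cannot be told apart, which a single measured benzyl compound could not show. The swap alters both the halogen and its place on the ring at once, and this one pair does not separate those two changes, nor does it show that they have no effect individually.

Steps involving compound 1 cannot be read, its value being a limit of the assay and not a number: the limit of > 200000 nM in this assay, at which 1 of the 3 values shown sits.

Open, as far as these compounds go, is whether any benzyl group at this position moves the read-out beyond the scatter, for instance one carrying an amine or a carboxylic acid on the phenyl ring, and how the unsubstituted benzyl group compares with the two halogenated ones.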